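A few compounds are considered here, and "the series" means these few. Any claim that something is new, unique, unknown or untested is made for them only; others in the source may bear on it.

In a functional assay on RAW264.7 cells (Mus musculus) for inhibition, read by Griess assay, with stated times of 1 h and 24 h (on this read-out lower numbers stand for stronger inhibition and higher numbers for weaker inhibition), compound 1 `CCOc1ccc(C(O)C2OC(=O)c3c(OC)cc(OC)cc32)cc1` gives > 10000 nM, which is a limit of the assay and not a number. Among the measured compounds shown here, compound 2 `CCCCOc1ccc(C(O)C2OC(=O)c3c(OC)cc(OC)cc32)cc1` gives 1800 nM, the only actual number so far, and it therefore has no measured neighbour to be ranked against precisely. Compound 3 `COCCOc1ccc(C(O)C2OC(=O)c3c(OC)cc(OC)cc32)cc1` keeps the shared core and changes the side chain, butoxy to 2-methoxyethoxy: methoxy in place of ethyl on a saturated chain carbon, two bonds along the chain from an oxygen on an aromatic ring. This is methoxy in place of ethyl on a saturated chain carbon, two bonds along the chain from an oxygen on an aromatic ring. For the measured compounds named here, one measured step bears on it, an at least 5.5-fold lower number from compound 1 to compound 2 (0.74 log units; beyond the scatter), which came with ethyl entering at that same place. Compound 3 gives up that ethyl but keeps a chain of similar length, so part of that gain is expected to be lost, and a smaller step towards higher numbers is expected in this assay. The expected change is a 2.5-fold higher number from compound 2 to compound 3 (0.40 log units; beyond the scatter). For compound 3 the estimated value is 4500 nM, with an expected range from 2000 nM to 10000 nM.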

Compound 3, half-maximal inhibitory concentration: > 10000 nM
Compound 3: no number, only a limit (the forecaster's own chance of this, stated with the estimate: 30%); middle value at least 2.2-fold (0.34 log units) from the limit.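

In this assay, methoxy in place of ethyl on a saturated chain carbon, two bonds along the chain from an oxygen on an aromatic ring, gives an at least 5.5-fold higher number from compound 2 to compound 3 (0.74 log units; beyond the scatter). Ethyl and methoxy both count 2 heavy atoms, with 1 oxygen and 1 hydrogen-bond acceptor entering in methoxy, so among these compounds a chain of matching size at this place did not by itself keep the lower number of compound 2. That step rests on a limit of the assay, its true size stays unknown, and the step from compound 1 to compound 3 cannot be read, with only compound 2 carrying an actual number: the limit of > 10000 nM in this assay, at which 2 of the 3 values shown sit.

The compounds shown leave open whether butoxy is a peak or only a point on a rising line, which a longer chain such as hexyloxy at the same place would test. They also leave open how other groups at the end of the chain would read in this assay, for instance a hydroxyl, an amine or a carboxylic acid in place of the ethyl of compound 2.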